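Hydroxymethyl to methoxycarbonyl: expected clearance of compound 3

The source may report more compounds than this note shows. Statements on the series, on what has been measured and on what is new or still open speak of the compounds shown alone.

In an in vitro ADME assay on microsomes from liver (Homo sapiens) for metabolic stability, tested at 1 uM (a higher number here means faster removal of the compound, a lower number slower removal), compound 1 (`Cc1cc(/C=C/C#N)cc(C)c1Oc1cc(Nc2ccc(C#N)cc2)c(N)cc1[N+](=O)[O-]`) gives 150 mL.min-1.g-1 and compound 2 (`Cc1cc(CCC#N)cc(C)c1Oc1cc(Nc2ccc(C#N)cc2)c(N)cc1CO`) gives 330 mL.min-1.g-1, the higher of the two numbers, with a gap beyond the scatter. Going by the values given here, these two compounds differ in more than one place, so they offer no single-change step. Compound 3 (`COC(=O)c1cc(N)c(Nc2ccc(C#N)cc2)cc1Oc1c(C)cc(CCC#N)cc1C`) carries methoxycarbonyl in place of hydroxymethyl on an aromatic carbon. Among the compounds with values here, no measured step covers this change, so no shift beyond the scatter is expected in this assay, and the estimated 1.2-fold lower number from compound 2 to compound 3 (0.07 log units; within the scatter) stays small. For compound 3 the estimated value is 280 mL.min-1.g-1 (range 120 mL.min-1.g-1 to 650 mL.min-1.g-1).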

Compound 3, intrinsic clearance in microsomes: 40 mL.min-1.g-1
Beside the measured number, compound 3's estimate is 7.0-fold (0.85 log units) above it; measured number below the stated range.
By their numbers in this assay, from the lowest: compound 3; then compound 1; then compound 2.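

Going by these compounds alone, the first single-change step shows that, in this assay, this aromatic carbon para to the (4-cyanophenyl)amino group is sensitive to substitution: methoxycarbonyl in place of hydroxymethyl gives an 8.3-fold lower number from compound 2 to compound 3 (0.92 log units; beyond the scatter). This is a single pair on one shared core, so it establishes no trend across the series. No available evidence accounts for the size of the step.

As far as these compounds go, whether a carboxylic acid or an amide at this position would track with methoxycarbonyl or with hydroxymethyl remains open. So does whether a longer ester would keep the lower number.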